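Carbamate aryl variation on the shared core

The source may report more compounds than this note shows. Statements on the series, on what has been measured and on what is new or still open speak of the compounds shown alone.

Measured compounds:
- Compound 1, `COc1nc(C)c(Nc2nc(Cl)cn([C@H](COC(=O)Nc3ccccc3Cl)C3CC3)c2=O)cc1C`: 1.5 nM
- Compound 2, `COc1nc(C)c(Nc2nc(Cl)cn([C@H](COC(=O)Nc3cc(Cl)cc(Cl)c3)C3CC3)c2=O)cc1C`: 1.7 nM

Both compounds share the same core and differ only in the aryl group on the carbamate nitrogen. In an assay on frontal cortex for displacement of a labelled ligand from corticotropin-releasing factor receptor 1 (Rattus norvegicus), with a stated time of 2 h (on this read-out lower numbers stand for stronger inhibition and higher numbers for weaker inhibition), compound 1 gives 1.5 nM and compound 2 gives 1.7 nM; the two numbers lie within the scatter of each other, so neither can be placed above the other. Within the data shown here, the one step available, a 1.1-fold higher number from compound 1 to compound 2 (0.05 log units; within the scatter), shows that exchanging one chlorinated aryl group for another on this nitrogen leaves the read-out unchanged.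

Compound 3, `COc1nc(C)c(Nc2nc(Cl)cn([C@H](COC(=O)Nc3cccc(C#N)c3)C3CC3)c2=O)cc1C`, is not yet measured. Its difference from compound 2 is 3-cyanophenyl in place of 3,5-dichlorophenyl on an amide-type nitrogen. Among the measured compounds shown here, no measured step covers a nitrile at this position, so the only guide is the indifference seen in a 1.1-fold higher number from compound 1 to compound 2 (0.05 log units; within the scatter). On that basis compound 3 is expected to stay within the scatter of compound 2, with a step of about a 1.5-fold higher number from compound 2 to compound 3 (0.17 log units; within the scatter); the estimate for compound 3 in this assay is 2.5 nM, with a range from 1 nM to 7 nM. For the measured compounds named here, the range is set wider than the measured step: no measured step covers a nitrile at this position.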

Compound 3, half-maximal inhibitory concentration: 1.3 nM
Estimate against measurement, compound 3: 1.9-fold (0.28 log units) above, and the stated range covers the measured number.
By their numbers in this assay, from the lowest: compounds 3, 1 and 2 (each within the scatter of the next).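

Up to this point, only chlorinated aryl groups had been compared on this amide-type nitrogen in this assay. With 3-cyanophenyl in place of 3,5-dichlorophenyl the result is a 1.3-fold lower number from compound 2 to compound 3 (0.12 log units; within the scatter), and with 3-cyanophenyl in place of 2-chlorophenyl it is a 1.2-fold lower number from compound 1 to compound 3 (0.06 log units; within the scatter). The read-out at this position therefore does not depend on a chlorine on the phenyl ring, as a nitrile, with its added hydrogen-bond acceptor by count, leaves compounds 1, 2 and 3 indistinguishable, and no measurement at hand bears on why this change leaves the read-out level.

Going by these compounds, all three compounds carry a substituted phenyl ring directly on this nitrogen, so the limit of this tolerance remains unknown. Still open, on these data alone, is whether the read-out would stay level with a carboxylic acid or an aminomethyl group on the phenyl ring, or with a benzyl group in place of the phenyl group on the amide-type nitrogen.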